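Dropping the aryl bromide from the benzyloxy series

The source may report more compounds than this note shows. Statements on the series, on what has been measured and on what is new or still open speak of the compounds shown alone.

Compound 3 `CC(NC(=O)N(C)S(=O)(=O)c1ccccc1)c1cc(Br)ccc1OCc1ccccc1` gives 60300 nM in a functional assay on thoracic aorta (Rattus norvegicus, strain Wistar), with a stated time of 15 min (on this read-out higher numbers stand for an effect only at larger amounts of compound and lower numbers for an effect already at smaller amounts), the highest of the three numbers in hand, though compound 2 `CC(NC(=O)N(C)S(=O)(=O)c1ccc(Cl)cc1)c1ccccc1OCc1ccccc1` at 38400 nM sits within the scatter of it; compound 1 `CCOc1ccc(Br)cc1C(C)NC(=O)N(C)S(=O)(=O)c1ccccc1` at 19800 nM lies furthest. Among the compounds with values here, the only single-place step measured, a 3.0-fold higher number from compound 1 to compound 3 (0.48 log units; beyond the scatter), concerns the group on the ether oxygen, not the bromine, so it does not bear directly on the next change. Compound 4 `CC(NC(=O)N(C)S(=O)(=O)c1ccccc1)c1ccccc1OCc1ccccc1` differs from compound 3 by hydrogen in place of bromo on an aromatic carbon. Within the data shown here, no measured pair isolates this change; compounds 2 and 3 differ in two places and their values are close. The step expected is a 1.2-fold lower number from compound 3 to compound 4 (0.08 log units; within the scatter), nothing beyond the scatter. Compound 4 is estimated at 50000 nM, within 20000 nM to 150000 nM.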

Compound 4, half-maximal effective concentration: 21700 nM
Estimate against measurement, compound 4: 2.3-fold (0.36 log units) above, within the range that was stated.
By their numbers in this assay, from the lowest: compounds 1, 4, 2 and 3 (each within the scatter of the next, the first and the last beyond it).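

Bromo is not neutral at this carbon para to the benzyloxy group: hydrogen in its place gives a 2.8-fold lower number from compound 3 to compound 4 (0.44 log units; beyond the scatter) in this assay. Hydrogen in place of chloro, at another aromatic carbon, gives a 1.8-fold lower number from compound 2 to compound 4 (0.25 log units; within the scatter) and so stays inside the usual spread. Nothing available here accounts for the bromo step.

On these data alone, whether a methoxy group or an amine at this carbon would read closer to bromo or to hydrogen remains open. Also open, as far as these compounds go, is whether the bromo step carries over when ethoxy replaces benzyloxy.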